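A few compounds are considered here, and "the series" means these few. Any claim that something is new, unique, unknown or untested is made for them only; others in the source may bear on it.

Compound 1 `Cc1ccc(S(=O)(=O)/C(=C/c2ccc(N(C)C)cc2)C(=O)c2ccc(Br)cc2)cc1`: 50000 nM
Compound 2 `Cc1ccc(S(=O)(=O)/C(=C/c2c[nH]c3ccc(Cl)cc23)C(=O)c2ccc(Br)cc2)cc1`: 10000 nM

Of the compounds shown here, two built on one shared core have been measured in a functional assay on DU-145 cells (Homo sapiens) for inhibition, read by trypan blue exclusion, with a stated time of 96 h; a higher number here means a weaker inhibitor of growth, a lower number a stronger inhibitor of growth. Compound 1 gives 50000 nM, and compound 2 gives 10000 nM. Among the compounds with values here, of these two numbers compound 2 stands lowest, so it is the stronger inhibitor of growth; the single measured step here is a 5.0-fold lower number from compound 1 to compound 2 (0.70 log units; beyond the scatter), a modest one, produced by exchanging the group on the double-bonded chain carbon.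

Compound 3 `Cc1ccc(S(=O)(=O)/C(=C/c2ccc(F)cc2F)C(=O)c2ccc(Br)cc2)cc1` alters that same position once more: 2,4-difluorophenyl in place of 5-chloro-1H-indol-3-yl on a double-bonded chain carbon bound to a double-bonded chain carbon. Within the data shown here, no measured step involves a 2,4-difluorophenyl group, so the only guide is that a change at this place moved the number by a 5.0-fold lower number from compound 1 to compound 2 (0.70 log units; beyond the scatter). The 2,4-difluorophenyl group resembles the 4-(dimethylamino)phenyl group of compound 1 more than the 5-chloro-1H-indol-3-yl group of compound 2, so the number is expected to drift back upward by about a 2.0-fold higher number from compound 2 to compound 3 (0.30 log units; within the scatter), with low confidence. Compound 3 is therefore expected to give 20000 nM in this assay, most likely between 5000 nM and 80000 nM.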

Compound 3, concentration for 50% growth inhibition: > 100000 nM
Compound 3 gave a limit, no number; the forecaster's own chance of this, stated with the estimate: 20%; middle value at least 5.0-fold (0.69 log units) from the limit.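

Compound 3 reaches only a limit in this assay, not a number: the limit of > 100000 nM in this assay, at which 1 of the 3 values shown sits. Even so, replacing 5-chloro-1H-indol-3-yl with 2,4-difluorophenyl gives an at least 10-fold higher number from compound 2 to compound 3 (1.00 log units; beyond the scatter), which makes compound 2 the strongest inhibitor of growth of these three and shows that the 2,4-difluorophenyl group does not keep the gain seen in a 5.0-fold lower number from compound 1 to compound 2 (0.70 log units; beyond the scatter). The comparison with the other phenyl-bearing compound is less firm, since an at least 2.0-fold higher number from compound 1 to compound 3 (0.30 log units; that floor lies within the scatter) leaves open how far apart the two compounds lie, but among these three compounds both groups built on phenyl stand on the weaker side of the indole-bearing compound 2.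

The exchange from compound 2 to compound 3 alters the ring system, the chlorine and the hydrogen-bond donor together, so these compounds cannot tell which of those differences carries the step. From the compounds shown here alone, an unsubstituted 1H-indol-3-yl group, a 5-fluoro-1H-indol-3-yl group or a plain phenyl group at this place would be needed to separate them, and the effect of changing the 4-bromophenyl group elsewhere on the shared core also remains open.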